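Working notes: from compound 2 to compound 3

A few compounds are considered here, and "the series" means these few. Any claim that something is new, unique, unknown or untested is made for them only; others in the source may bear on it.

- compound 1 `O=C(OC1CCC(CN2CCN(c3cc(=O)c4cc(C(F)(F)F)cc([N+](=O)[O-])c4s3)CC2)CC1)c1ccccc1`: 0.603 h
- compound 2 `O=C(OC1CCC(CN2CCN(c3cc(=O)c4cc(C(F)(F)F)cc([N+](=O)[O-])c4s3)CC2)CC1)c1ccncc1`: 0.075 h

In an ADME assay on cells (Hepatocyte, Homo sapiens) for metabolic stability (on this read-out higher numbers stand for a longer-lived compound and lower numbers for a shorter-lived compound), compound 2 holds the lower of the two numbers, at 0.075 h, and compound 1 gives 0.603 h. The change under consideration leads to compound 3 `Cc1ccc(C(=O)OC2CCC(CN3CCN(c4cc(=O)c5cc(C(F)(F)F)cc([N+](=O)[O-])c5s4)CC3)CC2)cc1`: 4-methylphenyl in place of pyridin-4-yl on a carbonyl carbon. In short, 4-methylphenyl stands in place of pyridin-4-yl on a carbonyl carbon.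

Going by the values given here, only one measured step bears on this: an 8.0-fold lower number from compound 1 to compound 2 (0.91 log units; beyond the scatter), with pyridin-4-yl in place of phenyl. That step is beyond the scatter, and the present change removes the same pyridin-4-yl, so a move in the opposite direction is expected, of similar size. Among the compounds with values here, this rests on a single pair, and no measured compound carries 4-methylphenyl, so the range is kept wide. The estimated step is a 6.7-fold higher number from compound 2 to compound 3 (0.82 log units; beyond the scatter), upward and expected to lie beyond the scatter. In this assay compound 3 is estimated at 0.5 h, with an expected range of 0.2 h to 1.2 h.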

Compound 3, half-life: 0.148 h
Estimate against measurement, compound 3: 3.4-fold (0.53 log units) above; the whole stated range lies above it.
By their numbers in this assay, from the lowest: compounds 2 and 3 (each within the scatter of the next); then compound 1.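

In this assay the exchange of pyridin-4-yl for 4-methylphenyl on the carbonyl carbon gives a 2.0-fold higher number from compound 2 to compound 3 (0.30 log units; within the scatter), so taking out the ring nitrogen does not by itself bring the number back to that of compound 1. The new information lies in the other pair: a 4.1-fold lower number from compound 1 to compound 3 (0.61 log units; beyond the scatter) comes with nothing more than methyl in place of hydrogen on an aromatic carbon, which shows that this position responds to a small addition on a carbon-only ring as well as to a hetero atom in the ring, and among these three compounds only the unsubstituted phenyl of compound 1 stands apart. There is no supporting measurement that would explain either step.

Open, as far as these compounds go, is whether the gap to compound 1 is specific to methyl or appears with other groups on the phenyl ring, such as a fluorine, a chlorine or a methoxy group. Also open, from the compounds shown here alone, is how a pyridin-3-yl or a saturated cyclohexyl ring on the same carbonyl carbon would read in this assay, and so whether an aromatic ring is needed there at all.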